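Phenyl for Methyl: Expected Cytotoxicity of Compound 3

A few compounds are considered here, and "the series" means these few. Any claim that something is new, unique, unknown or untested is made for them only; others in the source may bear on it.

Compound 1, `C=C1C(=O)O[C@@H](C2CCCCC2)[C@H]1c1ccccc1`: 104%
Compound 2, `C=C1C(=O)O[C@@H](c2ccccc2)[C@H]1C`: 62%

In a functional assay on PANC-1 cells (Homo sapiens) for cytotoxicity, read by MTT assay, with a stated time of 72 h, tested at 10 uM (on this read-out higher numbers stand for a weaker effect at the one concentration tested and lower numbers for a stronger effect), compound 2 gives 62%, the lowest of the two numbers; compound 1 gives 104%, a number higher beyond the scatter. Compound 3, `C=C1C(=O)O[C@@H](c2ccccc2)[C@H]1c1ccccc1`, is not yet measured. It differs from compound 2 by phenyl in place of methyl on a saturated ring carbon. For the measured compounds named here, no measured pair shows this change alone, and compound 1, which carries a phenyl at that place together with another difference, gives 104%, so a step towards a weaker effect is expected, of uncertain size. Compound 3 is expected at 85%, between 55% and 110%. That means an expected step of a number 23 percentage points higher from compound 2 to compound 3 (beyond the scatter).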

Compound 3, a percentage reported as activity, at one concentration (the size of the read-out at that concentration, not a potency): 38%
Compound 3: the middle estimate sits 47 percentage points above what was measured, and the stated range ends above it.
By their numbers in this assay, from the lowest: compound 3; then compound 2; then compound 1.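

In this assay, phenyl in place of methyl on this saturated ring carbon gives a number 24 percentage points lower from compound 2 to compound 3 (beyond the scatter), so the change strengthens the effect rather than weakening it. The phenyl at this place therefore does not account for the weak result of compound 1; changing the other ring substituent, phenyl in place of cyclohexyl, gives a number 66 percentage points lower from compound 1 to compound 3 (beyond the scatter). Compound 3, with phenyl at both places, is the strongest of the three. Nothing measured here gives a reason for either step. As far as these compounds go, whether an amine or a longer chain at this position would keep the effect remains open.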